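A few compounds are considered here, and "the series" means these few. Any claim that something is new, unique, unknown or untested is made for them only; others in the source may bear on it.

In a functional assay on MCF7 cells (Homo sapiens) for inhibition, read by MTT assay, with a stated time of 72 h (a lower number here means a stronger inhibitor, a higher number a weaker inhibitor), three compounds sharing one core have been measured so far:

Compound 1, `COc1ccc(-c2nnc(SCCCN3CCN(c4nc5ccccc5o4)CC3)o2)cc1`: 52800 nM
Compound 2, `O=[N+]([O-])c1ccc(-c2nnc(SCCCN3CCN(c4nc5ccccc5o4)CC3)o2)cc1`: 90100 nM
Compound 3, `Fc1ccc(-c2nnc(SCCCN3CCN(c4nc5ccccc5o4)CC3)o2)cc1`: 52300 nM

Compound 2 gives the highest of the three numbers, yet its nearest neighbour is compound 1, a 1.7-fold higher number from compound 1 to compound 2 (0.23 log units; within the scatter), and its furthest is compound 3, a 1.7-fold lower number from compound 2 to compound 3 (0.24 log units; within the scatter). Both gaps are within the scatter, so the three compounds cannot be ranked against one another on these numbers.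

The next compound, compound 4, `Oc1ccc(-c2nnc(SCCCN3CCN(c4nc5ccccc5o4)CC3)o2)cc1`, keeps the shared core and alters the same position on the outer phenyl ring once more: hydroxy in place of nitro on an aromatic carbon.

Among the measured compounds shown here, two measured steps bear on this change. Each of them also swaps the group at that same aromatic carbon: the step of a 1.7-fold higher number from compound 1 to compound 2 (0.23 log units; within the scatter) and the step of a 1.7-fold lower number from compound 2 to compound 3 (0.24 log units; within the scatter). Neither moved the number beyond the scatter, which suggests that this position tolerates different small groups without a clear effect in this assay. A hydroxy group has not been tried here, so no step beyond the scatter is expected in either direction.

Compound 4 is therefore expected to give about 60000 nM in this assay, within a range of 25000 nM to 150000 nM, which would mean a step of a 1.5-fold lower number from compound 2 to compound 4 (0.18 log units; within the scatter).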

Compound 4, half-maximal inhibitory concentration: 260000 nM
The estimate for compound 4 lay 4.3-fold (0.64 log units) below the measured number; the measured number lies above the stated range.
By their numbers in this assay, from the lowest: compounds 3, 1 and 2 (each within the scatter of the next); then compound 4.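

In this assay, among the compounds shown here, this aromatic carbon turns out not to accept every small group equally, as hydroxy is the first group to give a step beyond the scatter, and it does so against all three earlier groups (with a 2.9-fold higher number from compound 2 to compound 4 (0.46 log units; beyond the scatter), with a 5.0-fold higher number from compound 3 to compound 4 (0.70 log units; beyond the scatter), and with a 4.9-fold higher number from compound 1 to compound 4 (0.69 log units; beyond the scatter)). The last of these steps is the most telling, since the structures differ only by a methyl on the oxygen, so removing that one methyl separates two compounds in a way that the swaps among nitro, fluoro and methoxy did not. Nothing available here explains why the number rises with hydroxy.

Going by these compounds, it remains open whether this rise is particular to hydroxy or would also appear with other groups at this carbon, such as an amine or a carboxylic acid, or with plain hydrogen there. On these data alone, it is also open whether the same change would give a similar step on a related compound, for instance one with a longer chain on the sulfur.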